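This account rests on a few compounds, and the source may have more. Where it says the series, first, only, none or still open, it means among the compounds named here.

The study tracks four compounds in an ADME assay on HepG2 cells (Homo sapiens) for cytotoxicity, read by MTT assay, with a stated time of 48 h; a lower number here means that less compound is tolerated, a higher number that more compound is tolerated. Compound 1 `CC(=O)OC[C@H]1O[C@H](OC[C@H](Cn2cc(COc3ccc(-c4noc(C)n4)cc3)nn2)OC(C)=O)C=C[C@@H]1OC(C)=O` gives 37.7 ug/mL in this assay. Compound 3 `C#CCN(c1nc(-c2ccccc2)no1)C1CCCCC1` gives 109 ug/mL in this assay. Compound 2 `CC(=O)OC[C@H]1O[C@H](OC[C@@H](Cn2cc(CN(c3nc(-c4cccc([N+](=O)[O-])c4)no3)C3CCCCC3)nn2)OC(C)=O)C=C[C@@H]1OC(C)=O` is recorded in this assay only as > 200 ug/mL, which is a limit of the assay rather than a number, so its standing against the other two cannot be placed closer than that; the line the limit of > 200 ug/mL in this assay, at which 1 of the 3 values shown sits, notes that one of the three values sits at this limit.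

Compound 4 `CC(=O)OC[C@H]1O[C@H](OC[C@@H](Cn2cc(CN(c3nc(-c4ccc([N+](=O)[O-])cc4)no3)C3CCCCC3)nn2)OC(C)=O)C=C[C@@H]1OC(C)=O`, not yet measured in this assay, differs from compound 2 in one place: 4-nitrophenyl in place of 3-nitrophenyl on an aromatic carbon. For the measured compounds named here, no measured pair in the set differs in this way, so no step is known for such a change. With the same atoms joined only slightly differently, no shift beyond the usual scatter is expected in this assay, in either direction.

Compound 4 is therefore estimated at 200 ug/mL, within the range 100 ug/mL to 400 ug/mL, which means an expected step of a number no higher from compound 2 to compound 4 (the limit leaves the size open).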

Compound 4, half-maximal cytotoxic concentration: > 200 ug/mL
Compound 4 ended at the assay's limit (the forecaster's own chance of this, stated with the estimate: 70%); the middle value sits exactly at the limit.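

In this assay compound 2 and compound 4 both stand at a limit rather than at a number, so no step between them can be read: the limit of > 200 ug/mL in this assay, at which 2 of the 4 values shown sit.

The compounds shown leave open whether 4-nitrophenyl in place of 3-nitrophenyl changes the tolerated concentration at all, and in which direction.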